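The source may hold more compounds than are shown below. What is called first, only, known or untested is meant among the compounds shown, and "the series" means these compounds.

Compound 3 `Cc1cc(C(=O)NCc2ccncc2)nn1Cc1cc(Cl)ccc1OCc1ccccc1` is measured in a physicochemical assay for lipophilicity, at pH 7.4 (on this read-out lower numbers stand for lower lipophilicity and higher numbers for higher lipophilicity), only as a limit, > 3.7. Compound 2 `Cc1cc(C(=O)NCc2cccnc2)nn1Cc1cc(Cl)ccc1OCc1ccccc1` likewise gives only a limit in this assay, > 3.7. Compound 1 `Cc1cc(C(=O)Nc2ccc(F)cc2)nn1Cc1cc(Cl)ccc1OCc1ccccc1` gives a number in this assay, 3. The step of a number at least 0.70 log units higher from compound 1 to compound 2 (beyond the scatter) and the step of a number at least 0.70 log units higher from compound 1 to compound 3 (beyond the scatter) are both read against those limits, and the step that the two limits leave unreadable from compound 2 to compound 3 cannot be sized, since both of its values sit at the limit of > 3.7 in this assay, at which 2 of the 3 values shown sit.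

Compound 4 `Cc1cc(NC(=O)c2c(F)cccc2F)nn1Cc1cc(Cl)ccc1OCc1ccccc1` has not yet been measured in this assay. It differs from compound 3 in one place: ((2,6-difluorophenyl)carbonyl)amino in place of ((pyridin-4-yl)methyl)carbamoyl on an aromatic carbon. Going by the values given here, none of the measured steps changes exactly this place. The closest guide is compound 1, which carries a 4-fluorophenyl on its amide nitrogen and gives 3 in this assay, together with the step of a number at least 0.70 log units higher from compound 1 to compound 3 (beyond the scatter). Compound 4 returns to an aromatic ring of carbon only in place of the ring with one hetero atom, so a step back toward the value of compound 1 is expected, estimated as a number at least 0.30 log units lower from compound 3 to compound 4 (that floor lies within the scatter). For compound 4 the expected value in this assay is 3.4, estimated to lie between 2.8 and 4, with a fair chance that this assay again reports only a limit.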

Compound 4, distribution coefficient: > 3.7
Compound 4 was reported as a limit (the forecaster's own chance of this, stated with the estimate: 35%); at least 0.30 log units between middle value and limit.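

In this assay compound 4 gives only a limit, > 3.7. Going by these compounds alone, until now, the readable rise from compound 1 had been seen only with a (pyridin-3-yl)methyl or (pyridin-4-yl)methyl group on the amide nitrogen, but ((2,6-difluorophenyl)carbonyl)amino on this aromatic carbon, with no ring hetero atom in the group, also gives a number at least 0.70 log units higher from compound 1 to compound 4 (beyond the scatter). Compound 1 and compound 4 both carry a six-membered aromatic ring of carbon only, so among these compounds such a ring does not by itself bring the value back to that of compound 1.

Going by these compounds, the steps among compound 2, compound 3 and compound 4 cannot be read, so their order stays open: the limit of > 3.7 in this assay, at which 3 of the 4 values shown sit. Also open, on these data alone, is what an amine or a carboxylic acid on this aromatic carbon, or a longer chain on the amide nitrogen, would give in this assay.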